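The source may report more compounds than this note shows. Statements on the series, on what has been measured and on what is new or still open speak of the compounds shown alone.

Compound 1 `CC(=O)OC[C@H]1O[C@@H](OCCCCCCCCCCCCCCC(C)C(=O)C2=C(O)N(C)C(C)C2=O)[C@@H](O)[C@@H](O)[C@@H]1O` gives 29000 nM in a functional assay on HeLa cells (Homo sapiens) for cytotoxicity; on this read-out lower numbers stand for higher toxicity in this test and higher numbers for lower toxicity in this test. Compound 2 `CC(CCCCCCCCCCCCCCO[C@@H]1O[C@H](CO)[C@@H](O)[C@H](O)[C@@H]1O)C(=O)C1=C(O)N(C)C(C)C1=O` reaches only the limit of the test, > 90000 nM in this assay, so its standing is known only as a limit. Among the compounds with values here, the single measured step, an at least 3.1-fold higher number from compound 1 to compound 2 (0.49 log units; beyond the scatter), is hydrogen in place of acetyl on an oxygen on a saturated carbon, and its size is bounded only because of the limit of > 90000 nM in this assay, at which 1 of the 2 values shown sits. Compound 3 `CC(=O)O[C@@H]1[C@H](O)[C@H](OCCCCCCCCCCCCCCC(C)C(=O)C2=C(O)N(C)C(C)C2=O)O[C@H](CO)[C@H]1O` carries acetyl in place of hydrogen on an oxygen on a saturated carbon, the acetyl returning on an oxygen on a saturated carbon whose other neighbour is a saturated ring carbon. Compound 3 is therefore expected to show an at least 2.0-fold lower number from compound 2 to compound 3 (0.30 log units; that floor lies within the scatter), a move back toward lower numbers. Compound 3 is estimated at 45000 nM, within 15000 nM to 130000 nM.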

Compound 3, half-maximal cytotoxic concentration: 44200 nM
The estimate for compound 3 lay 1.0-fold (0.01 log units) above the measured number; the range from low to high includes it.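

Placed on an oxygen on a saturated carbon whose other neighbour is a saturated ring carbon, the acetyl again comes with an at least 2.0-fold lower number from compound 2 to compound 3 (0.30 log units; that floor lies within the scatter). As far as these compounds go, the true size of this step stays unknown, as its floor rests on a limit for compound 2: the limit of > 90000 nM in this assay, at which 1 of the 3 values shown sits. In this assay compound 1 gives 29000 nM and compound 3 gives 44200 nM, two values within the usual scatter of each other, so the two acetyl placements cannot be told apart. Still open, from the compounds shown here alone, is how a benzoyl group or a longer acyl chain on this oxygen would read, and whether an amine in place of the hydroxy would read the same.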